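From a fluorophenyl to a dimethoxyphenyl on the shared core

The compounds below may be only part of what the source reports. "The series", "measured", "known", "first", "only" and "open" are said of these compounds alone.

Compound 1, `O/N=C1\CCCc2onc(-c3cccc(F)c3)c21`: in a functional assay on HCC1954 cells (Homo sapiens) for antiproliferative activity, read by MTT assay, with a stated time of 72 h (a lower number here means a stronger inhibitor, a higher number a weaker inhibitor), compound 1 gives > 25000 nM, a limit of the assay.
Compound 2, `CC1(C)C/C(=N\OC(=O)c2cccc(NC(=O)c3cccc(F)c3)c2)c2c(-c3ccc(F)cc3)noc2C1`: in this assay compound 2 gives > 25000 nM, again a limit.
Compound 3, `CC1(C)C/C(=N\OC(=O)c2cccc(NC(=O)c3cccc(F)c3)c2)c2c(-c3cccc(F)c3)noc2C1`: in this assay compound 3 gives > 25000 nM, also a limit.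

Compound 3 therefore stands where every measured compound stands, as the limit of > 25000 nM in this assay, at which 3 of the 3 values shown sit, shows; no number sets it apart from compound 1 or compound 2. Among the measured compounds shown here, the one measured step that changes a single place, a step that the two limits leave unreadable from compound 2 to compound 3, cannot be read because both ends are limits.

Compound 4, `COc1ccc(-c2noc3c2/C(=N/OC(=O)c2cccc(NC(=O)c4cccc(F)c4)c2)CC(C)(C)C3)cc1OC`, differs from compound 3 by 3,4-dimethoxyphenyl in place of 3-fluorophenyl on an aromatic carbon. For the measured compounds named here, no measured step bears on this exchange, and the only step near it is unreadable. The expectation rests solely on the three limits. Compound 4 is thus expected to give about 25000 nM, most likely reported as a limit again, within a range from 5000 nM to 100000 nM. This corresponds to an expected step of a number no higher from compound 3 to compound 4 (the limit leaves the size open), meaning no change beyond the scatter. Whether compound 4 breaks this pattern is what the measurement will tell.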

Compound 4, half-maximal inhibitory concentration: > 25000 nM
Compound 4 gave a limit, no number (the forecaster's own chance of this, stated with the estimate: 70%); the middle value sits exactly at the limit.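

The steps to compound 4 from compound 3 and from compound 2 cannot be read, as both ends of each are limits: the limit of > 25000 nM in this assay, at which 4 of the 4 values shown sit.

The compounds shown leave open whether 3-fluorophenyl, 4-fluorophenyl and 3,4-dimethoxyphenyl differ at all in this assay, and whether any compound on the shared core gives a number there rather than a limit.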